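The source may report more compounds than this note shows. Statements on the series, on what has been measured and on what is new or still open speak of the compounds shown alone.

Compound 1, `CC(=O)Nc1c(C(O)(C(F)(F)F)C(F)(F)F)ccc2ccccc12`: 18 nM
Compound 2, `C/C=C/C(=O)Nc1c(C(O)(C(F)(F)F)C(F)(F)F)ccc2ccccc12`: 72 nM
Compound 3, `O=C(Nc1c(C(O)(C(F)(F)F)C(F)(F)F)ccc2ccccc12)C1CCC1`: 45 nM

All three were tested in an assay on LtK cells with ATP-sensitive inward rectifier potassium channel 11 (Homo sapiens) as the target; on this read-out higher numbers stand for an effect only at larger amounts of compound and lower numbers for an effect already at smaller amounts. Compound 1 stands at the lowest number of the three. Its nearest neighbour is compound 3, with a 2.5-fold higher number from compound 1 to compound 3 (0.40 log units; beyond the scatter), and its furthest is compound 2, with a 4.0-fold higher number from compound 1 to compound 2 (0.60 log units; beyond the scatter). Between the other two, a 1.6-fold lower number from compound 2 to compound 3 (0.20 log units; within the scatter), so compound 2 and compound 3 cannot be told apart on these numbers.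

Compound 4, `O=C(CC1CCCC1)Nc1c(C(O)(C(F)(F)F)C(F)(F)F)ccc2ccccc12`, is the next compound to be tested. It differs from compound 1 in one place: cyclopentyl in place of hydrogen on a saturated chain carbon bound to a carbonyl carbon. The two measured steps that bear on this both start from compound 1 and both alter the group on the carbonyl carbon away from methyl, and both raised the number by a modest amount: a 4.0-fold higher number from compound 1 to compound 2 (0.60 log units; beyond the scatter) and a 2.5-fold higher number from compound 1 to compound 3 (0.40 log units; beyond the scatter). Compound 4 alters that same part of the molecule, so a modest upward step is expected here too, about a 3.1-fold higher number from compound 1 to compound 4 (0.49 log units; beyond the scatter). Compound 4 is therefore estimated at 55 nM, with a range from 20 nM to 150 nM.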

Compound 4, half-maximal effective concentration: 81 nM
For compound 4 the middle estimate is 1.5-fold (0.17 log units) below the measured one; measured number inside the range.
By their numbers in this assay, from the lowest: compound 1; then compounds 3, 2 and 4 (each within the scatter of the next).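

Among the compounds shown here, replacing the methyl of compound 1 with cyclopentylmethyl, which brings in a five-membered ring of carbon only, again gives a higher number (a 4.5-fold higher number from compound 1 to compound 4 (0.65 log units; beyond the scatter)), so all three replacements at this position so far move the same way in this assay, and none goes against this. Compound 4 cannot be told apart from the two earlier replacements (a 1.8-fold higher number from compound 3 to compound 4 (0.26 log units; within the scatter); a 1.1-fold higher number from compound 2 to compound 4 (0.05 log units; within the scatter)), so adding a ring on a saturated chain carbon bound to the carbonyl carbon shows no clear difference from them. Nothing in the data offers a reason for this.

As far as these compounds go, it remains open whether a straight longer chain, such as propyl, would behave like cyclopentylmethyl. From the compounds shown here alone, it is equally open whether a carboxylic acid or an amine on this chain would bring the number back towards that of compound 1.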